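A Single Fluoro Change at the Assay Limit

The source may report more compounds than this note shows. Statements on the series, on what has been measured and on what is new or still open speak of the compounds shown alone.

Compound 1 (`Nc1ccn([C@H]2O[C@@H](CO)C=C2F)c(=O)n1`) gives > 100000 nM in a functional assay on Vero cells (Chlorocebus sabaeus) for inhibition (on this read-out higher numbers stand for weaker inhibition and lower numbers for stronger inhibition), and this is a limit of the assay, not an exact number. Compound 2 (`OC[C@H]1C=C(F)[C@H](n2cnc3c(O)ncnc32)O1`) gives > 100000 nM in this assay, which is again only a limit. Compound 3 (`Nc1nc(=O)n([C@H]2O[C@@H](CO)C=C2F)cc1F`) keeps the core of compound 1 and carries a single change (fluoro in place of hydrogen on an aromatic carbon), with fluoro in place of hydrogen on an aromatic carbon, ortho to an amino group. Within the data shown here, no measured step between similar compounds is available as a guide. Resting on compound 1 and the one shared result (the limit of > 100000 nM in this assay, at which 2 of the 2 values shown sit) alone, the expected step (a number no higher from compound 1 to compound 3 (the limit leaves the size open)) in this assay is none beyond the usual scatter. Compound 3 is expected at 100000 nM in this assay, with an estimated range from 30000 nM to 100000 nM and a strong chance that only a limit is reported.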

Compound 3, half-maximal inhibitory concentration: > 100000 nM
Compound 3: a limit, no number; the forecaster's own chance of this, stated with the estimate: 80%; the middle value sits exactly at the limit.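

Among these compounds, compound 1 and compound 3 both sit at a limit in this assay and give no exact number, so no step between them can be read. From the compounds shown here alone, whether fluoro in place of hydrogen on an aromatic carbon changes inhibition at all stays open, as does the true strength of each compound.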